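Acetylated pyrazole variant of an antiproliferative amide

The compounds below may be only part of what the source reports. "The series", "measured", "known", "first", "only" and "open" are said of these compounds alone.

Compound 2 `CNC(=O)N1CCCc2ccc(NC(=O)c3cccc(-c4cc[nH]n4)c3)cc21` gives 27.3% in a functional assay on MV4-11 cells (Homo sapiens) for antiproliferative activity, with a stated time of 6 days, tested at 1.56 uM (a higher number here means a stronger effect of the compound at the concentration tested, a lower number a weaker effect), the higher of the two numbers seen, while compound 1 `CNC(=O)N1CCCc2ccc(NC(=O)c3cccc(-c4ccccc4)c3)cc21` gives 2.83%. For the measured compounds named here, the only step measured, a number 24.5 percentage points higher from compound 1 to compound 2 (beyond the scatter), concerns a different change. Compound 3 `CNC(=O)N1CCCc2ccc(NC(=O)c3cccc(-c4cnn(C(C)=O)c4)c3)cc21` carries 1-acetyl-1H-pyrazol-4-yl in place of 1H-pyrazol-3-yl on an aromatic carbon. Going by the values given here, no measured step tests an acetyl on the pyrazole nitrogen or a changed attachment point, so the expectation rests loosely on compound 2 with its value of 27.3% and allows a decline. Compound 3 is estimated at 15%, between 0% and 35%, which would mean an expected step of a number 12.3 percentage points lower from compound 2 to compound 3 (beyond the scatter).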

Compound 3, a percentage reported as inhibition, at one concentration (the size of the read-out at that concentration, not a potency): 33.6%
Compound 3: the middle estimate sits 18.6 percentage points below what was measured; the measured number falls inside the stated range.
By their numbers in this assay, from the lowest: compound 1; then compounds 2 and 3 (each within the scatter of the next).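

In this assay, the change to 1-acetyl-1H-pyrazol-4-yl gives a number 6.3 percentage points higher from compound 2 to compound 3 (within the scatter), so this position accepts the acetyl and the shifted ring attachment together. The step of a number 30.8 percentage points higher from compound 1 to compound 3 (beyond the scatter) shows that the gain over phenyl persists without the hydrogen-bond donor of 1H-pyrazol-3-yl. No evidence here explains these results.

From the compounds shown here alone, the acetyl and the attachment point changed together, so their separate contributions remain unknown. A plain 1H-pyrazol-4-yl, or a 1-methyl-1H-pyrazol-4-yl, would help to separate them.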